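The compounds below may be only part of what the source reports. "The series", "measured", "known", "first", "only" and "open" are said of these compounds alone.

Measured so far in an ADME assay on microsomes from liver (Mus musculus, strain CD-1) for metabolic stability, read by LC-MS, tested at 2 uM; on this read-out lower numbers stand for a shorter-lived compound and higher numbers for a longer-lived compound:

- compound 1, `CN1CCC(CNS(=O)(=O)c2ccccc2Nc2cc(-c3ccc4ccn(C)c4c3)c3nccnc3c2)C1`: 0.633 h
- compound 2, `CC(=O)N1CCC(NC(=O)c2ccncc2Nc2cc(-c3ccc4ccn(C)c4c3)c3nccnc3c2)CC1`: 0.117 h

Compound 2 holds the lower of the two numbers in this assay; compound 1 sits higher, and the gap between the two lies beyond the scatter. For the measured compounds named here, the two differ in several places at once, so no single step between them can be read out, and only the two values themselves are known.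

Compound 3, `CC(=O)N1CC(CNC(=O)c2ccncc2Nc2cc(-c3ccc4ccn(C)c4c3)c3nccnc3c2)C1`, is the next member and is still to be measured in this assay. It is made from compound 2 by one change: (1-acetylazetidin-3-yl)methyl in place of 1-acetylpiperidin-4-yl on an amide-type nitrogen. The amide and the rest of the shared core are kept.

There is no measured step of this kind in the series to lean on. With the amide kept and one saturated ring exchanged for another of similar make-up, the step from compound 2 to compound 3 is expected to be a 1.3-fold higher number from compound 2 to compound 3 (0.11 log units; within the scatter), not beyond the scatter in either direction. Compound 3 is therefore estimated at 0.15 h in this assay, with a range from 0.06 h to 0.4 h.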

Compound 3, half-life: > 1 h
Compound 3 was reported as a limit (the forecaster's own chance of this, stated with the estimate: 5%); middle value at least 6.6-fold (0.82 log units) from the limit.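

In this assay, for the compounds shown here, (1-acetylazetidin-3-yl)methyl in place of 1-acetylpiperidin-4-yl on an amide-type nitrogen gives an at least 8.5-fold higher number from compound 2 to compound 3 (0.93 log units; beyond the scatter), the first step that can be read at a single place. It shows that this position on the amide is not a silent one: with the amide, the acetyl group and the rest of the shared core kept, exchanging this one saturated substituent moves the half-life beyond the scatter. Compound 3 is reported only as a limit of the assay, > 1 h, so the step gives a lower bound on the change and not its full size: the limit of > 1 h in this assay, at which 1 of the 3 values shown sits.

The step changes the ring and the way it is attached together, so the compounds shown cannot tell whether the four-membered ring or the methyl link carries the gain, and 1-acetylazetidin-3-yl or (1-acetylpiperidin-4-yl)methyl on the same amide-type nitrogen would pull the two apart. Also open, as far as these compounds go, is whether the acetyl group matters to this result, which a free azetidine amine or a methanesulfonyl group in its place would address.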